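A few compounds are considered here, and "the series" means these few. Any claim that something is new, unique, unknown or untested is made for them only; others in the source may bear on it.

In a toxicity assay on MT4 cells (Homo sapiens) for cytotoxicity, read by MTT assay, with a stated time of 5 days (on this read-out higher numbers stand for lower toxicity in this test and lower numbers for higher toxicity in this test), compound 3 `Cc1cc(-c2cncnc2)cc(C)c1Nc1ccnc(Nc2ccc(C#N)cc2)n1` gives 6800 nM, the highest of the three numbers shown. Among the compounds with values here, compound 1 `Cc1cnc(Nc2ccc(C#N)cc2)nc1Nc1c(F)cc(-c2cccnc2)cc1F` gives 1100 nM and compound 2 `Cc1cnc(Nc2ccc(C#N)cc2)nc1Nc1c(F)cc(-c2cncnc2)cc1F` gives 900 nM in this assay; the only measured step between two compounds that differ in one place, a 1.2-fold lower number from compound 1 to compound 2 (0.09 log units; within the scatter), concerns pyrimidin-5-yl in place of pyridin-3-yl on an aromatic carbon and stays within the scatter. Compound 4 `Cc1cc(-c2cnc(C(F)(F)F)nc2)cc(C)c1Nc1ccnc(Nc2ccc(C#N)cc2)n1` has not yet been measured. It differs from compound 3 by trifluoromethyl in place of hydrogen on an aromatic carbon; cut one bond further out, the change reads pyrimidin-5-yl to 2-(trifluoromethyl)pyrimidin-5-yl. Within the data shown here, no measured step shows what trifluoromethyl in place of hydrogen on an aromatic carbon does in this assay; the one measured step swaps one ring for another and is not a guide here. With nothing to lean on, the number for compound 4 is expected to stay near that of compound 3, with the expected step of a 1.1-fold lower number from compound 3 to compound 4 (0.05 log units; within the scatter) lying within the scatter. Compound 4 is estimated at 6000 nM, in a range from 2000 nM to 20000 nM.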

Compound 4, half-maximal cytotoxic concentration: 4900 nM
For compound 4 the middle estimate is 1.2-fold (0.09 log units) above the measured one; the range from low to high includes it.
By their numbers in this assay, from the lowest: compounds 2 and 1 (each within the scatter of the next); then compounds 4 and 3 (each within the scatter of the next).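

Trifluoromethyl in place of hydrogen on the aromatic carbon between two ring nitrogen atoms, para to a large group, is a change that the earlier compounds did not cover, and in this assay it gives a 1.4-fold lower number from compound 3 to compound 4 (0.14 log units; within the scatter). This position therefore takes on 4 heavy atoms with no reading beyond the scatter, so compound 3 and compound 4 cannot be told apart in this test. No separate measurement is available to explain this result.

On these data alone, it remains open whether an amine, a carboxylic acid or a longer chain at this carbon would also stay within the scatter of compound 3. Also open, as far as these compounds go, is whether the same trifluoromethyl change on compound 2, which carries the same pyrimidin-5-yl, would give a step of similar size.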